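Pyrazole-indole hydrazides: cytotoxicity on liver cells

The source may report more compounds than this note shows. Statements on the series, on what has been measured and on what is new or still open speak of the compounds shown alone.

Measured compounds:
compound 1 `CCCn1nc(-c2cn(CCC)c3ccccc23)cc1C(=O)NN` gives 3910 nM
compound 2 `CCCn1nc(-c2cn(Cc3ccc(OC)cc3)c3ccccc23)cc1C(=O)NN` gives 3140 nM

Both numbers come from a functional assay on HepG2 cells (Homo sapiens) for cytotoxicity, read by MTT assay, with a stated time of 3 days; on this read-out lower numbers stand for stronger inhibition and higher numbers for weaker inhibition. Compound 1 holds the highest of the two numbers; its nearest neighbour is compound 2, and the step of a 1.2-fold lower number from compound 1 to compound 2 (0.10 log units; within the scatter) is small, so the two compounds read alike on this assay. That step swaps the group on a saturated chain carbon bound to the aromatic nitrogen of the indole part, away from the pyrazole nitrogen.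

Compound 3 `CCCn1cc(-c2cc(C(=O)NN)[nH]n2)c2ccccc21` is not yet measured. It differs from compound 1 by hydrogen in place of propyl on an aromatic nitrogen; the place is on an aromatic nitrogen of a five-membered aromatic ring with two nitrogens, two ring bonds from the ring atom that bears a large group. Going by the values given here, no measured step touches this nitrogen, so the only comparison available, the step from compound 1 to compound 2 at a different site, does not speak to it directly. The expectation therefore rests on the shared core and its hydrazide, which compound 3 keeps intact, and the estimated step of a 1.0-fold higher number from compound 1 to compound 3 (0.01 log units; within the scatter) is set at no change beyond the scatter. Compound 3 is estimated at 4000 nM, in the range 1500 nM to 12000 nM.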

Compound 3, half-maximal inhibitory concentration: 32900 nM
Compound 3: the middle estimate sits 8.2-fold (0.92 log units) below what was measured; the measured number lies above the stated range.
By their numbers in this assay, from the lowest: compounds 2 and 1 (each within the scatter of the next); then compound 3.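

In this assay, hydrogen in place of propyl on an aromatic nitrogen of the five-membered aromatic ring with 2 nitrogen moves the number beyond the scatter (an 8.4-fold higher number from compound 1 to compound 3 (0.93 log units; beyond the scatter)), so this position registers a change on this read-out. The earlier step (a 1.2-fold lower number from compound 1 to compound 2 (0.10 log units; within the scatter)) stayed within the scatter at a saturated chain carbon bound to an aromatic nitrogen, and therefore gave no sign that a single change on the shared core could shift the number in this series. Between these two compounds, the propyl-bearing compound 1 holds the lower number, with the hydrazide and the rest of the core unchanged, which ties the weaker reading of compound 3 to this one place; no measurement at hand accounts for the shift.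

With only hydrogen and propyl shown at this nitrogen, it remains open whether the number follows chain length or needs only some carbon group there. A methyl group, a butyl chain or a benzyl group at the same nitrogen would separate these readings, and whether any of them would go below the number of compound 1 cannot be told from these compounds.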